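Halogen swap on the core: fluoro to chloro

The source may hold more compounds than are shown below. What is called first, only, known or untested is meant among the compounds shown, and "the series" means these compounds.

Compound 1 `O=c1c2ccccc2ccn1[C@@H]1O[C@H](COP(=O)(O)OP(=O)(O)OP(=O)(O)O)[C@@H](O)[C@H]1O` in a functional assay for agonist activity at P2Y purinoceptor 1 (Homo sapiens), read by FLIPR (on this read-out lower numbers stand for an effect already at smaller amounts and higher numbers for an effect only at larger amounts of compound), gives > 20000 nM, which is a limit of the assay rather than a number.
Compound 2 `O=c1c2cc(F)ccc2ccn1[C@@H]1O[C@H](COP(=O)(O)OP(=O)(O)OP(=O)(O)O)[C@@H](O)[C@H]1O` in this assay gives > 20000 nM, again a limit and not a number.

Compound 2 therefore stands at the edge of what this assay can report; the limit of > 20000 nM in this assay, at which 2 of the 2 values shown sit, shows both measured values sitting at that same limit. The step that the two limits leave unreadable from compound 1 to compound 2 is consequently unreadable in size and direction, since neither end of it is a number.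

Compound 3 `O=c1c2cc(Cl)ccc2ccn1[C@@H]1O[C@H](COP(=O)(O)OP(=O)(O)OP(=O)(O)O)[C@@H](O)[C@H]1O` differs from compound 2 by chloro in place of fluoro on an aromatic carbon. Going by the values given here, the only measured step that bears on this change is the one from compound 1 to compound 2, the introduction of fluoro at the same place, and it gave no readable size. There is thus no basis for expecting a step beyond the scatter in either direction in this assay, and the most likely outcome is that compound 3 also returns only a limit.

Compound 3 is expected at 30000 nM, with a range from 10000 nM to 100000 nM. The estimated step that the limit leaves unreadable from compound 2 to compound 3 is expected to be flat within the scatter.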

Compound 3, half-maximal effective concentration: > 20000 nM
Compound 3: a limit, no number (the forecaster's own chance of this, stated with the estimate: 85%); the middle value is on the limit's open side.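

Compound 3, like compound 1 and compound 2, returns only a limit in this assay, so none of the steps among these three compounds can be read in size or direction: the limit of > 20000 nM in this assay, at which 3 of the 3 values shown sit.

The compounds shown leave open whether hydrogen, fluoro and chloro at this place on the shared core differ at all in agonist activity.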